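A few compounds are considered here, and "the series" means these few. Any claim that something is new, unique, unknown or untested is made for them only; others in the source may bear on it.

Compound 1, `CCOc1cccc2cc(-c3ccc(OC)c(OC)c3)c(=O)oc12`; compound 2, `O=c1oc2c(O)cccc2cc1-c1ccccc1`; compound 3, `O=c1oc2c(O)c(O)ccc2cc1-c1ccccc1`.

In an assay on CHO cells for displacement of a labelled ligand from adenosine receptor A2b (Homo sapiens), read by radioligand binding (on this read-out lower numbers stand for stronger inhibition and higher numbers for weaker inhibition), compound 1 gives > 30000 nM, which is a limit of the assay rather than a number. Compound 2 likewise gives > 30000 nM, again a limit. Compound 3 gives > 30000 nM, also a limit. So compound 3 stands nowhere above or below its neighbours on the numbers shown: all three values sit together at the limit of > 30000 nM in this assay, at which 3 of the 3 values shown sit, and no compound can be called stronger or weaker than another.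

Going by the values given here, one measured step differs in a single place, the one from compound 2 to compound 3, a step that the two limits leave unreadable from compound 2 to compound 3; because both ends are limits, its size cannot be read.

Compound 4 is `O=c1oc2c(O)c(O)ccc2cc1-c1ccc(O)cc1`. It differs from compound 3 by hydroxy in place of hydrogen on an aromatic carbon. Among the compounds with values here, the only measured step of the same kind, from compound 2 to compound 3, gave no readable size, so there is no measured basis for expecting a change beyond the scatter, and the most probable outcome for compound 4 is another limit. Compound 4 is therefore expected at 40000 nM, within a range from 10000 nM to 150000 nM. This amounts to an expected step that the limit leaves unreadable from compound 3 to compound 4.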

Compound 4, inhibition constant: > 30000 nM
Compound 4 ended at the assay's limit; the forecaster's own chance of this, stated with the estimate: 85%; the middle value lies beyond the limit too.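

Compound 3 and compound 4 both stand at a limit of this assay, so no new step can be read between them. The compounds shown leave open what any change on the shared core does to the inhibition constant, as none of them gives a readable number: the limit of > 30000 nM in this assay, at which 4 of the 4 values shown sit.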